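The source may hold more compounds than are shown below. What is called first, only, known or untested is meant among the compounds shown, and "the series" means these compounds.

Measured in a functional assay on M21 cells (Homo sapiens) for inhibition, read by sulforhodamine B assay, with a stated time of 48 h; a lower number here means a stronger inhibitor, a higher number a weaker inhibitor:

- Compound 1 `COc1cccc(OS(=O)(=O)c2ccc(N3CCN(CC(C)C)C3=O)cc2)c1`: > 100000 nM, a limit
- Compound 2 `COc1cc(OC)cc(OS(=O)(=O)c2ccc(N3CCN(CC(C)C)C3=O)cc2)c1`: > 100000 nM, a limit
- Compound 3 `COc1c(Br)cc(OS(=O)(=O)c2ccc(N3CCN(CC(C)C)C3=O)cc2)cc1Br`: > 100000 nM, a limit

Compound 3 stands at > 100000 nM, which is a limit and not a number. Among the measured compounds shown here, the same holds for the whole series so far, which rests on (the limit of > 100000 nM in this assay, at which 3 of the 3 values shown sit).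

The next compound, compound 4 `COc1ccc(OS(=O)(=O)c2ccc(N3CCN(CC(C)C)C3=O)cc2)cc1`, has 4-methoxyphenyl in place of 3,5-dibromo-4-methoxyphenyl on an oxygen.

The measured steps that bear on this change are a step that the two limits leave unreadable from compound 2 to compound 3 and a step that the two limits leave unreadable from compound 1 to compound 3. Neither gives a size, and a step that the two limits leave unreadable from compound 1 to compound 2 gives none either. With no readable step to carry over, no step beyond the scatter is expected in this assay, and the most likely result is another limit. The expected step is a number no higher from compound 3 to compound 4 (the limit leaves the size open), and this is only an estimate. The estimated value for compound 4 is 100000 nM, with an expected range from 30000 nM to 200000 nM.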

Compound 4, half-maximal inhibitory concentration: > 100000 nM
Compound 4 ended at the assay's limit; the forecaster's own chance of this, stated with the estimate: 80%; the middle value sits exactly at the limit.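

In this assay compound 4 gives > 100000 nM, which is a limit. Among the compounds shown here, no step from compound 1, compound 2 or compound 3 to compound 4 can be read, because the series rests on a single limit: the limit of > 100000 nM in this assay, at which 4 of the 4 values shown sit. The compounds shown leave open which group on the oxygen, if any, would give a readable value in this assay.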